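Aryl variation at the shared core: compound 3 to compound 4

A few compounds are considered here, and "the series" means these few. Any claim that something is new, unique, unknown or untested is made for them only; others in the source may bear on it.

Measured so far in an assay for binding affinity to dual specificity mitogen-activated protein kinase kinase 4 (Homo sapiens), read by KINOMEscan, tested at 100 nM; on this read-out lower numbers stand for a stronger effect and higher numbers for a weaker effect at the one concentration tested:
compound 1, `CCCS(=O)(=O)Nc1ccc(F)c(C(=O)c2n[nH]c3ncc(-c4cccc(F)c4)cc23)c1F`: 8.2%
compound 2, `CCCS(=O)(=O)Nc1ccc(F)c(C(=O)c2n[nH]c3ncc(-c4ccc(Cl)cc4Cl)cc23)c1F`: 22%
compound 3, `CCCS(=O)(=O)Nc1ccc(F)c(C(=O)c2n[nH]c3ncc(-c4cc(Cl)cc(Cl)c4)cc23)c1F`: 73%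

Compound 3 gives the highest of the three numbers; its nearest neighbour is compound 2 (a number 51 percentage points higher from compound 2 to compound 3 (beyond the scatter)) and its furthest compound 1 (a number 64.8 percentage points higher from compound 1 to compound 3 (beyond the scatter)), both gaps beyond the scatter, so compound 3 is the weakest binder of the three.

Compound 4, `CCCS(=O)(=O)Nc1ccc(F)c(C(=O)c2n[nH]c3ncc(-c4ccc(C(F)(F)F)cc4)cc23)c1F`, differs from compound 3 in one place: 4-(trifluoromethyl)phenyl in place of 3,5-dichlorophenyl on an aromatic carbon. All three measured steps change the same aromatic carbon's substituent, so all bear on it. Two of them lead into compound 3 and are large (a number 64.8 percentage points higher from compound 1 to compound 3 (beyond the scatter), a number 51 percentage points higher from compound 2 to compound 3 (beyond the scatter)); the third, a number 13.8 percentage points higher from compound 1 to compound 2 (beyond the scatter), is modest. Going by the values given here, every other aryl group tested sits well below compound 3, and no step concerns a trifluoromethyl group directly. For compound 4 the step expected in this assay is therefore a number 43 percentage points lower from compound 3 to compound 4 (beyond the scatter), a sizeable estimate that carries wide uncertainty.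

Compound 4 is estimated at 30%, within a range of 8% to 65%.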

Compound 4, a percentage reported as activity, at one concentration (the size of the read-out at that concentration, not a potency): 29%
Compound 4: the middle estimate sits 1 percentage points above what was measured; the measured number falls inside the stated range.
By their numbers in this assay, from the lowest: compound 1; then compounds 2 and 4 (each within the scatter of the next); then compound 3.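

At this aromatic carbon in this assay, 4-(trifluoromethyl)phenyl replaces 3,5-dichlorophenyl with a number 44 percentage points lower from compound 3 to compound 4 (beyond the scatter), so the high number of compound 3 is not a general result of a larger substituent: the entering group has 10 heavy atoms against 8 for the one leaving. The step of a number 7 percentage points higher from compound 2 to compound 4 (within the scatter) places 4-(trifluoromethyl)phenyl level with 2,4-dichlorophenyl, so, among the four aryl groups shown, two different substitution patterns give readings that cannot be separated in this assay, and compound 3 is the only one that stands apart at the high end. With a number 20.8 percentage points higher from compound 1 to compound 4 (beyond the scatter), 3-fluorophenyl still gives the lowest number of the four, and its step to each of the other compounds lies beyond the scatter.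

No available evidence accounts for the differences among these aryl groups. On these data alone, every aryl group here carries only fluorine, chlorine or trifluoromethyl, so it remains open whether an amine, a carboxylic acid or a methoxy group on the phenyl ring would give a number nearer to that of compound 1 or that of compound 3.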